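A few compounds are considered here, and "the series" means these few. Any claim that something is new, unique, unknown or untested is made for them only; others in the source may bear on it.

Three compounds have so far been measured in a functional assay for agonist activity at Free fatty acid receptor 1 (Homo sapiens), read by FLIPR, in the presence of a further agent that is not named here; a lower number here means that less compound is needed, a higher number that more compound is needed for the effect:

Compound 1, `O=C1NC(=O)C(Cc2ccc(Oc3ncc(Cl)cc3Cl)cc2)S1`, gives 90 nM in this assay.
Compound 2, `Cc1ccc(Oc2ccc(CC3SC(=O)NC3=O)cc2)nc1`, gives 4470 nM in this assay.
Compound 3, `O=C1NC(=O)C(Cc2ccc(Oc3ncc(C(F)(F)F)cc3Cl)c3ccccc23)S1`, gives 23600 nM in this assay.

Compound 2 stands second highest of these three numbers. Its nearest neighbour is compound 3, whose number is higher by a margin beyond the usual scatter; compound 1 lies far below compound 2, again well beyond the scatter, and is the lowest of the three.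

Compound 4, `O=C1NC(=O)C(Cc2ccc(Oc3ccc(Cl)cn3)cc2)S1`, differs from compound 2 in one place: chloro in place of methyl on an aromatic carbon. Among the compounds with values here, no measured pair shows this exact change, so its size must be judged from what the three numbers show. Within the data shown here, a drop in the number, rather than a rise, is expected, because compound 1 with its two chloro groups gives 90 nM and is the only compound here that carries chlorine on that ring. Among the measured compounds shown here, a moderate step is expected, since compound 4 carries only a single chloro where compound 1 has two.

Compound 4 is therefore expected to give about 700 nM in this assay, most likely between 150 nM and 3000 nM. The expected step of a 6.4-fold lower number from compound 2 to compound 4 (0.81 log units; beyond the scatter) is thus a clear but not dramatic fall, beyond the scatter.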

Compound 4, half-maximal effective concentration: 1870 nM
For compound 4 the middle estimate is 2.7-fold (0.43 log units) below the measured one; low and high end bracket the measured number.
By their numbers in this assay, from the lowest: compound 1; then compound 4; then compound 2; then compound 3.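

In this assay, replacing 5-methylpyridin-2-yl with 5-chloropyridin-2-yl gives a 2.4-fold lower number from compound 2 to compound 4 (0.38 log units; beyond the scatter), so this position responds to the change, but only modestly. Much more hangs on the second chloro of compound 1: putting hydrogen in its place gives a 21-fold higher number from compound 1 to compound 4 (1.32 log units; beyond the scatter), so the single chloro that compound 1 shares with compound 4 does not by itself deliver the low number of compound 1. Nothing measured here explains why either step has the size it has.

On these data alone, it remains open whether a nitrile or a methoxy group at the position of the single chloro would go further than chloro or methyl. As far as these compounds go, it is equally open whether a fluoro or a methyl group could stand in for the second chloro of compound 1 and keep its low number.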